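Compound 3 to compound 4: benzoyl swapped for phenylsulfonyl

The compounds below may be only part of what the source reports. "The series", "measured", "known", "first", "only" and "open" are said of these compounds alone.

Compound 3 `O=C1Nc2ccc(S(=O)(=O)N3CCOCC3)cc2/C1=N/NC(=O)c1ccccc1` stands highest of three in a functional assay on MCF7 cells (Homo sapiens) for cytotoxicity, read by sulforhodamine B assay, with a stated time of 24 h (on this read-out lower numbers stand for stronger inhibition and higher numbers for weaker inhibition), at 414000 nM while compound 2 `CC(=O)N/N=C1\C(=O)Nc2ccc(S(=O)(=O)N3CCOCC3)cc21` gives 56000 nM and compound 1 `N#CCC(=O)N/N=C1\C(=O)Nc2ccc(S(=O)(=O)N3CCOCC3)cc21` gives 27700 nM on the same core. Compound 4 `O=C1Nc2ccc(S(=O)(=O)N3CCOCC3)cc2/C1=N/NS(=O)(=O)c1ccccc1` carries phenylsulfonyl in place of benzoyl on an amine nitrogen. Among the compounds with values here, no measured step makes this exchange, so the evidence is indirect. The nearest steps are those that bring in phenyl on the carbonyl carbon: a 7.4-fold higher number from compound 2 to compound 3 (0.87 log units; beyond the scatter) and a 15-fold higher number from compound 1 to compound 3 (1.17 log units; beyond the scatter), modest and large. Both leave compound 3 at the top of the span, so any change seems likelier to go downward. For compound 4 a modest step to a lower number is expected (a 2.8-fold lower number from compound 3 to compound 4 (0.44 log units; beyond the scatter)). Compound 4 is estimated at 150000 nM (expected range 40000 nM to 450000 nM).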

Compound 4, half-maximal inhibitory concentration: 25300 nM
Compound 4: middle estimate off by 5.9-fold (0.77 log units), on the high side; the whole stated range lies above it.
By their numbers in this assay, from the lowest: compounds 4 and 1 (each within the scatter of the next); then compound 2; then compound 3.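

In this assay, phenyl on this amine nitrogen does not by itself go with a weak number: exchanging benzoyl for phenylsulfonyl recovers the whole span of the series (a 16-fold lower number from compound 3 to compound 4 (1.21 log units; beyond the scatter)). Phenylsulfonyl also stands apart from acetyl (a 2.2-fold lower number from compound 2 to compound 4 (0.35 log units; beyond the scatter)), but not from (cyanomethyl)carbonyl (a 1.1-fold lower number from compound 1 to compound 4 (0.04 log units; within the scatter)), so a bulky aromatic group is tolerated here when joined through sulfonyl. No supporting measurement accounts for the gap between the carbonyl and sulfonyl links.

Open, going by these compounds, is whether methylsulfonyl on this nitrogen gives a number like that of compound 4. Also open, on these data alone, is how a methoxy group or chlorine on the phenyl ring of phenylsulfonyl would shift it.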